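Trading a Cyclohexyl Ring for an Ethyl Chain

A few compounds are considered here, and "the series" means these few. Any claim that something is new, unique, unknown or untested is made for them only; others in the source may bear on it.

Compound 3 `Nc1cc(C2CCCCC2)nc2ccc(NC(=O)/C=C/c3ccc(C(F)(F)F)cc3)cc12` gives 1.2 nM in an assay on isolated protein for displacement of a labelled ligand from melanin-concentrating hormone receptor 1 (Homo sapiens); a lower number here means a stronger inhibitor, a higher number a weaker inhibitor. Among the three measured compounds it has the second highest number; its nearest neighbour is compound 1 `Nc1cc(C2CCCC2)nc2ccc(NC(=O)/C=C/c3ccc(C(F)(F)F)cc3)cc12` at 0.8 nM, and compound 2 `Nc1cc(C2CCC2)nc2ccc(NC(=O)/C=C/c3ccc(C(F)(F)F)cc3)cc12` is furthest at 2 nM, both within the scatter. Compound 4 `CCc1cc(N)c2cc(NC(=O)/C=C/c3ccc(C(F)(F)F)cc3)ccc2n1` carries ethyl in place of cyclohexyl on an aromatic carbon, a larger change than any measured step. The steps of a 2.5-fold higher number from compound 1 to compound 2 (0.40 log units; beyond the scatter), a 1.5-fold higher number from compound 1 to compound 3 (0.18 log units; within the scatter) and a 1.7-fold lower number from compound 2 to compound 3 (0.22 log units; within the scatter) vary ring size only, and only the smallest ring moved the number beyond the scatter, upward. Because of a 2.5-fold higher number from compound 1 to compound 2 (0.40 log units; beyond the scatter), a further cut to an open ethyl chain is expected to raise the number somewhat more. Compound 4 is therefore estimated at 4 nM, between 1.5 nM and 12 nM, meaning an expected step of a 3.3-fold higher number from compound 3 to compound 4 (0.52 log units; beyond the scatter).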

Compound 4, half-maximal inhibitory concentration: 1.2 nM
Beside the measured number, compound 4's estimate is 3.3-fold (0.52 log units) above it; measured number below the stated range.
By their numbers in this assay, from the lowest: compounds 1, 3, 4 and 2 (each within the scatter of the next, the first and the last beyond it).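

At this position a ring is not needed for a low number: in this assay, ethyl, with 2 heavy atoms and no ring, matches cyclohexyl, with 6 heavy atoms (no change at the digits printed from compound 3 to compound 4 (within the scatter)). Ethyl also stays within the scatter of both other rings (a 1.7-fold lower number from compound 2 to compound 4 (0.22 log units; within the scatter); a 1.5-fold higher number from compound 1 to compound 4 (0.18 log units; within the scatter)), so the rise seen with cyclobutyl does not continue as the group shrinks further. No measurement shown explains why the short chain does as well as the rings.

As far as these compounds go, whether a methyl group, a longer chain such as butyl, or an amine would also be tolerated here remains open.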